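This account rests on a few compounds, and the source may have more. Where it says the series, first, only, none or still open, it means among the compounds named here.

In a functional assay on KB 3-1 cells (Homo sapiens), with a stated time of 1 h (on this read-out higher numbers stand for an effect only at larger amounts of compound and lower numbers for an effect already at smaller amounts), compound 1 (`CC(=O)Oc1cc2oc(-c3ccccc3)cc(=O)c2c(OC(C)=O)c1OC(C)=O`) gives 6800 nM, at the high end of the measured set. Compound 2 (`CC(=O)Oc1cc2oc(-c3ccccc3)cc(=O)c2c(OCc2ccccc2)c1OC(C)=O`) at 3700 nM lies within the scatter of it, while compound 3 (`CC(=O)Oc1cc2oc(-c3ccccc3)cc(=O)c2c(O)c1OCc1ccccc1`) at 2400 nM lies lower, beyond the scatter. Unmeasured compound 4 (`CC(=O)Oc1c(OCc2ccccc2)cc2oc(-c3ccccc3)cc(=O)c2c1OC(C)=O`) differs from compound 1 thus: benzyl in place of acetyl on an oxygen on an aromatic ring. In words, this is benzyl in place of acetyl on an oxygen on an aromatic ring. Among the compounds with values here, the one measured step of this kind, a 1.8-fold lower number from compound 1 to compound 2 (0.26 log units; within the scatter), makes the same exchange on a different oxygen. A similar small drop, not beyond the scatter, is therefore expected. The expected step is a 1.7-fold lower number from compound 1 to compound 4 (0.23 log units; within the scatter). Compound 4 is estimated at 4000 nM, with an expected range of 1800 nM to 8500 nM.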

Compound 4, half-maximal effective concentration: 1100 nM
Estimate against measurement, compound 4: 3.6-fold (0.56 log units) above, outside the stated range (below it).
By their numbers in this assay, from the lowest: compound 4; then compounds 3, 2 and 1 (each within the scatter of the next, the first and the last beyond it).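

With benzyl in place of acetyl on this oxygen there is a 6.2-fold lower number from compound 1 to compound 4 (0.79 log units; beyond the scatter) and the step lies beyond the scatter, whereas the same exchange on a different oxygen gave a 1.8-fold lower number from compound 1 to compound 2 (0.26 log units; within the scatter) and stayed within it. Within the data shown here, the size of this exchange therefore depends on which oxygen carries it, something the earlier compounds could not show. No supporting data bear on why the two steps differ.

Still open, going by these compounds, is how a longer alkyl chain or an amine in place of acetyl on this oxygen would read. Also open, on these data alone, is whether a substituted benzyl would follow the same step.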